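Benzyl in place of phenyl on two related cores

A few compounds are considered here, and "the series" means these few. Any claim that something is new, unique, unknown or untested is made for them only; others in the source may bear on it.

Compound 1 `O=C1NC(=O)/C(=C/c2ccc(OCCSc3nnc(-c4ccccc4)[nH]3)cc2)S1` and compound 2 `O=C1NC(=O)/C(=C/c2ccc(OCCSc3nnc(Cc4ccccc4)[nH]3)cc2)S1` share one core. In a functional assay on the whole organism (plasma, strain Wistar) with Rattus norvegicus as the target, with a stated time of 15 days, at a dose of 10 mg/kg by the oral route (on this read-out lower numbers stand for a weaker effect and higher numbers for a stronger effect at the one dose given), compound 1 gives 10.6%, and compound 2 gives 19.4%. The change between them is benzyl in place of phenyl on an aromatic carbon, and it made a step of a number 8.8 percentage points higher from compound 1 to compound 2 (within the scatter).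

Compound 3 `O=C1NC(=O)/C(=C/c2ccc(OCCSc3nnc(-c4ccccc4)o3)cc2)S1` has a different core; the difference between the two cores is not broken down here. In this assay compound 3 gives 14.6%. Compound 4 `O=C1NC(=O)/C(=C/c2ccc(OCCSc3nnc(Cc4ccccc4)o3)cc2)S1` is not yet measured and differs from compound 3 by benzyl in place of phenyl on an aromatic carbon. This is the same kind of change as from compound 1 to compound 2, but the place is not the same: in compound 1 the carbon sits in a five-membered aromatic ring with 3 nitrogen, between two ring nitrogen atoms, while in compound 3 it sits in a five-membered aromatic ring with 2 nitrogen and 1 oxygen, next to the ring nitrogen and next to the ring oxygen.

The earlier step lay within the scatter, and on that rests the expectation that compound 4 shows a step of a number 5.4 percentage points higher from compound 3 to compound 4 (within the scatter) in this assay. Compound 4 is therefore estimated at 20%, between 9% and 31%.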

Compound 4, a percentage reported as activity, at one dose (the size of the read-out at that dose, not a potency): 16.8%
Estimate against measurement, compound 4: 3.2 percentage points above, within the range that was stated.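

On the second core, benzyl in place of phenyl gave, in this assay, a step of a number 2.2 percentage points higher from compound 3 to compound 4 (within the scatter). Set beside the step on the first core, the two cannot be told apart: the same change on two cores in this assay, a number 8.8 percentage points higher (within the scatter) from compound 1 to compound 2 and a number 2.2 percentage points higher (within the scatter) from compound 3 to compound 4, 6.6 percentage points apart, within the scatter of two such steps. The change therefore carried across these two cores without a detectable difference, but with both steps inside the scatter, this does not show that it has a real effect on either core, nor that it would transfer to a third.

The compounds shown leave open what a longer chain, such as phenethyl, would do at this place on either core. The same holds for an amine or a carboxylic acid there.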